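Adding a methyl to the phenyl of compound 1

This account rests on a few compounds, and the source may have more. Where it says the series, first, only, none or still open, it means among the compounds named here.

Compound 1 `COC(=O)N1N=C(c2ccccc2)CC1c1cc(OC)c(OC)c(OC)c1` gives 2880 nM in a functional assay on A549 cells (Homo sapiens) for antiproliferative activity, read by MTT assay, with a stated time of 48 h (on this read-out lower numbers stand for stronger inhibition of growth and higher numbers for weaker inhibition of growth), the lowest of the numbers obtained so far. In this assay compound 3 `COC(=O)N1N=C(c2ccccc2)CC1c1ccc(OC)c(OC)c1` gives 7320 nM. Compound 2 `CCCOC(=O)N1N=C(c2ccccc2)CC1c1cc(OC)c(OC)c(OC)c1` gives > 10000 nM, which is a limit of the assay and not a number.

Two single changes to compound 1 have been measured, and both raised the number beyond the scatter. Ethyl in place of hydrogen on the saturated chain carbon bound to an oxygen gave an at least 3.4-fold higher number from compound 1 to compound 2 (0.54 log units; beyond the scatter). Hydrogen in place of methoxy on an aromatic carbon gave a 2.5-fold higher number from compound 1 to compound 3 (0.41 log units; beyond the scatter).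

Compound 4 `COC(=O)N1N=C(c2cccc(C)c2)CC1c1cc(OC)c(OC)c(OC)c1` has not yet been measured. It differs from compound 1 by methyl in place of hydrogen on an aromatic carbon, which turns phenyl to 3-methylphenyl. Neither measured change touches this phenyl, so they offer only loose guidance. The closest guide is the modest 2.5-fold higher number from compound 1 to compound 3 (0.41 log units; beyond the scatter), also a change on an aromatic carbon. A small rise in this assay is therefore expected, quite possibly none beyond the scatter. The estimated step is a 1.2-fold higher number from compound 1 to compound 4 (0.08 log units; within the scatter). For compound 4 the expected value is 3500 nM, with an estimated range from 1300 nM to 9000 nM.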

Compound 4, concentration for 50% growth inhibition: 300 nM
Compound 4: the middle estimate sits 12-fold (1.07 log units) above what was measured, and the stated range ends above it.
By their numbers in this assay, from the lowest: compound 4; then compound 1; then compound 3. At a limit, above all of these: compound 2.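

The phenyl of compound 1 turns out to be a sensitive place, where one added carbon changes the read-out strongly: in this assay, methyl in place of hydrogen on this ring gave a 9.6-fold lower number from compound 1 to compound 4 (0.98 log units; beyond the scatter). Both earlier single changes, made elsewhere on compound 1, raised the number, so this is the first change shown that moves it downward, and it shows that the parent compound can be improved as well as weakened by a small edit. Nothing measured here accounts for why so small a change has so large an effect.

The compounds shown cannot tell whether the gain belongs to methyl itself or to this particular place on the ring, since a single group at a single position gives nothing to compare it with; a chlorine atom or an amine on the same carbon, or a methyl on a different carbon of the phenyl, would separate the two readings. Also open, going by these compounds, is whether the same methyl would lower the number on compound 3, whose other ring differs.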